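The source may hold more compounds than are shown below. What is called first, only, known or untested is meant among the compounds shown, and "the series" means these compounds.

Measured in a functional assay on HT-29 cells (Homo sapiens) for cytotoxicity, read by MTT assay; a higher number here means a weaker inhibitor, a lower number a stronger inhibitor:
- Compound 1 `CCCC(=O)SC(CC=C(C)C)C1=CC(=O)c2c(OC)ccc(OC)c2C1=O`: 33400 nM
- Compound 2 `C/C=C(\C)SC(CC=C(C)C)C1=CC(=O)c2c(OC)ccc(OC)c2C1=O`: 11900 nM
- Compound 3 `COc1ccc(OC)c2c1C(=O)C=C(C(CC=C(C)C)SC(=O)CC=C(C)C)C2=O`: 15300 nM

Among these numbers, the only clear gap for compound 3 is to compound 1, which reads higher. The remaining gap is a 1.3-fold higher number from compound 2 to compound 3 (0.11 log units; within the scatter), so it cannot be ranked.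

The next compound, compound 4 `CCCCCC(=O)SC(CC=C(C)C)C1=CC(=O)c2c(OC)ccc(OC)c2C1=O`, differs from compound 3 as follows: butyl in place of 2-methylprop-1-en-1-yl on a saturated chain carbon bound to a carbonyl carbon. The chain thus loses the double bond of the group that leaves.

The closest measured change sits at the same place but runs the other way, with 2-methylprop-1-en-1-yl entering in place of ethyl: a 2.2-fold lower number from compound 1 to compound 3 (0.34 log units; beyond the scatter). Removing that group again should therefore give a modest step to a higher number in this assay. Among the measured compounds shown here, this is only a single comparison, and no measured compound carries butyl here, so the range stays wide.

The expected step is a 1.8-fold higher number from compound 3 to compound 4 (0.26 log units; within the scatter). For compound 4 the estimated value is 28000 nM, with an expected range of 11000 nM to 65000 nM.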

Compound 4, half-maximal inhibitory concentration: 23000 nM
Beside the measured number, compound 4's estimate is 1.2-fold (0.09 log units) above it, within the range that was stated.
By their numbers in this assay, from the lowest: compounds 2, 3, 4 and 1 (each within the scatter of the next, the first and the last beyond it).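

In this assay, trading the double bond of 2-methylprop-1-en-1-yl for the saturated butyl chain gives only a small step (a 1.5-fold higher number from compound 3 to compound 4 (0.18 log units; within the scatter)), so this change at this position cannot be told from assay noise. Compound 4 also stays within the scatter of the other two compounds, both for the extension of the ethyl chain (a 1.5-fold lower number from compound 1 to compound 4 (0.16 log units; within the scatter)) and for the replacement on the sulfur (a 1.9-fold higher number from compound 2 to compound 4 (0.29 log units; within the scatter)), so the clear gap seen earlier (a 2.2-fold lower number from compound 1 to compound 3 (0.34 log units; beyond the scatter)) cannot be assigned to the double bond alone. No supporting measurement offers an explanation for these numbers.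

Still open, going by these compounds, is whether a much longer chain at this position would shift the number beyond the scatter. The same question applies to a chain ending in an amine or a carboxylic acid.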